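This account rests on a few compounds, and the source may have more. Where it says the series, first, only, none or still open, it means among the compounds named here.

Working notes on the series in a functional assay on MCF7 cells (Homo sapiens) for antiproliferative activity, read by MTT assay; a lower number here means a stronger inhibitor, a higher number a weaker inhibitor.

Compound 1 `NS(=O)(=O)c1cccc(/N=C2\NC(=O)/C(=C3/C(=O)Nc4ccccc43)S2)c1` is known only as a limit in this assay. In this assay compound 1 gives > 200000 nM, a limit of the assay and not a number. Compound 2 `NS(=O)(=O)c1cccc(/N=C2\NC(=O)/C(=C3/C(=O)Nc4ccc(Cl)cc43)S2)c1` carries chloro in place of hydrogen on an aromatic carbon of the shared core. In this assay compound 2 likewise gives > 200000 nM, again a limit of the assay. The step that the two limits leave unreadable from compound 1 to compound 2 therefore cannot be read; both values sit at the same limit, as the limit of > 200000 nM in this assay, at which 2 of the 2 values shown sit, records.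

Compound 3 `NS(=O)(=O)c1cccc(/N=C2\NC(=O)/C(=C3/C(=O)N(Cc4ccccc4)c4ccccc43)S2)c1` is the next member. Relative to compound 1 the change is benzyl in place of hydrogen on an amide-type nitrogen in a ring. The only measured step in the set, the one from compound 1 to compound 2, is unreadable, so no measured step bears on a change at the amide-type nitrogen in a ring; no direction can be derived from the data shown for this assay. With both measured members of the series at the limit, the expectation for compound 3 is a step that the limit leaves unreadable from compound 1 to compound 3 that stays within the scatter. Compound 3 is accordingly estimated at 250000 nM, with a range from 80000 nM to 800000 nM, and most likely reported only as a limit.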

Compound 3, half-maximal inhibitory concentration: > 200000 nM
Compound 3: no number, only a limit; the forecaster's own chance of this, stated with the estimate: 85%; the middle value is on the limit's open side.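

In this assay compound 3 gives > 200000 nM, a limit of the assay and not a number. No new step can be read from compound 1 to compound 3, as the series stays at one limit: the limit of > 200000 nM in this assay, at which 3 of the 3 values shown sit.

The compounds shown leave open whether chloro on an aromatic carbon or benzyl on the amide-type nitrogen in a ring changes the read-out in this assay at all.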